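The source may hold more compounds than are shown below. What is called first, only, known or untested is meant among the compounds shown, and "the series" means these compounds.

Four compounds sharing one core are at issue here, and three of them have been measured in a functional assay on Huh-7 cells (Homo sapiens) for antiproliferative activity, read by CCK-8 assay, with a stated time of 72 h; a higher number here means a weaker inhibitor of growth, a lower number a stronger inhibitor of growth. Compound 2 `CCC1C(=O)N(C)c2cnc(-n3ccc4cc(C(=O)NC)ccc43)nc2N1c1ccn(C)n1` gives 13200 nM. Compound 1 `CCC1C(=O)N(C)c2cnc(Nc3ccc(S(=O)(=O)NCC(C)C)cc3)nc2N1c1ccn(C)n1` gives 8520 nM, which lies within the usual scatter of compound 2. Compound 3 `CCCCNS(=O)(=O)c1ccc(Nc2ncc3c(n2)N(c2ccn(C)n2)C(CC)C(=O)N3C)cc1` gives 3750 nM, a number clearly lower than that of compound 2. Compound 2 therefore stands at the high end of this small set, together with compound 1.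

Compound 4 `CCCNC(=O)c1ccc2c(ccn2-c2ncc3c(n2)N(c2ccn(C)n2)C(CC)C(=O)N3C)c1` differs from compound 2 by one change: ethyl in place of hydrogen on a saturated chain carbon bound to an amide-type nitrogen. Put another way, methylcarbamoyl becomes propylcarbamoyl.

Among the compounds with values here, only one measured step offers any guidance. It is a 2.3-fold lower number from compound 1 to compound 3 (0.36 log units; beyond the scatter), which comes with propyl in place of isopropyl on a saturated chain carbon bound to a sulfonamide nitrogen. That step is modest, and it involves a different group on a different kind of nitrogen, so it is a loose guide at best. Within the data shown here, no measured pair shows a change on the amide-type nitrogen itself. A small move toward a lower number is therefore expected, one that may not clear the scatter. The expected step is a 1.7-fold lower number from compound 2 to compound 4 (0.22 log units; within the scatter). The estimate for compound 4 is 8000 nM, with an expected range from 3500 nM to 18000 nM.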

Compound 4, concentration for 50% growth inhibition: 7280 nM
Compound 4: the middle estimate sits 1.1-fold (0.04 log units) above what was measured; measured number inside the range.
By their numbers in this assay, from the lowest: compounds 3, 4, 1 and 2 (each within the scatter of the next, the first and the last beyond it).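

In this assay, within the data shown here, the swap of methylcarbamoyl for propylcarbamoyl gives a 1.8-fold lower number from compound 2 to compound 4 (0.26 log units; within the scatter), which is the first measured step on this amide-type nitrogen. Such a step cannot be told apart from the ordinary spread of repeat measurements, so ethyl in place of hydrogen on this saturated chain carbon leaves the two compounds reading alike, and a propyl group is accepted here without a clear loss or gain in growth inhibition. Nothing available explains this outcome or connects it to any measured property of the compounds.

Going by these compounds, how far this acceptance extends remains open: a butyl group or a still longer chain on the same nitrogen might leave the number unmoved or shift it clearly, and two compounds alone cannot show which. A chain ending in an amine or a carboxylic acid, or a bare amide hydrogen in place of the methyl, could also behave quite differently, and the compounds shown offer no way to judge that.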